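Extending the Chain on the Shared Core Toward Compound 3

This account rests on a few compounds, and the source may have more. Where it says the series, first, only, none or still open, it means among the compounds named here.

Compound 1 `CN(C)/N=N/c1ccc(C(N)=O)cc1`: 3.51
Compound 2 `CCN(C)/N=N/c1ccc(C(N)=O)cc1`: 3.66

Both compounds were tested in a functional assay on L1210 cells (Mus musculus) for antiproliferative activity; on this read-out higher numbers stand for higher potency (the scale is a negative logarithm) and lower numbers for lower potency. On the numbers shown, compound 2 stands alongside compound 1: the step of a number 0.15 log units higher from compound 1 to compound 2 (within the scatter) lies within the scatter, so nothing separates them.

Compound 3 `CCCCCCCCN(C)/N=N/c1ccc(C(N)=O)cc1` is not yet measured. It differs from compound 2 by hexyl in place of hydrogen on a saturated chain carbon, two bonds along the chain from an amine nitrogen. Among the compounds with values here, the only measured step that bears on this change, a number 0.15 log units higher from compound 1 to compound 2 (within the scatter), also added carbon to this chain and was small. Within the data shown here, with one small step as the sole guide, no step beyond the scatter is expected. Compound 3 is therefore expected to give about 3.85, within 3.3 to 4.4, an expected step of a number 0.19 log units higher from compound 2 to compound 3 (within the scatter).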

Compound 3, logarithm of the reciprocal of the active concentration, log(1/C): 2.84
Beside the measured number, compound 3's estimate is 1.01 log units above it, outside the stated range (below it).
By their numbers in this assay, from the lowest: compound 3; then compounds 1 and 2 (each within the scatter of the next).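

At this position, chain length does matter: in this assay hexyl in place of hydrogen gives a number 0.82 log units lower from compound 2 to compound 3 (beyond the scatter) and heptyl in place of hydrogen gives a number 0.67 log units lower from compound 1 to compound 3 (beyond the scatter) on the same chain. The earlier pair showed only a small addition that changed nothing beyond the scatter, whereas these longer additions lower the number beyond it. No measurement shown here explains the fall. On these data alone, it remains open at what length the fall sets in, which a propyl or butyl chain could show, and whether an octyl chain ending in a carboxylic acid would behave the same way.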